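Working notes: removing one chloro from compound 2

This account rests on a few compounds, and the source may have more. Where it says the series, first, only, none or still open, it means among the compounds named here.

Measured in a functional assay on L02 cells (Homo sapiens) for inhibition, read by MTT assay, with a stated time of 72 h; on this read-out higher numbers stand for weaker inhibition and lower numbers for stronger inhibition:
- Compound 1 `C=C(c1ccc(Cl)c(Cl)c1)C1COC2(CCCCC2)OO1`: 83500 nM
- Compound 2 `C=C(c1ccc(Cl)c(Cl)c1Cl)C1COC2(CCCC2)OO1`: 1190 nM

Compound 2 stands lowest of the pair at 1190 nM, and compound 1, at 83500 nM, lies beyond the scatter from it. Among the measured compounds shown here, these two differ in more than one place, so no single-change step is available as a guide. Compound 3 `C=C(c1ccc(Cl)cc1Cl)C1COC2(CCCC2)OO1` departs from compound 2 by one change: hydrogen in place of chloro on an aromatic carbon. A moderate rise toward weaker inhibition in this assay is expected, probably beyond the scatter but with little certainty. The expected move is a 2.9-fold higher number from compound 2 to compound 3 (0.47 log units; beyond the scatter). For compound 3 the estimated value is 3500 nM, with an expected range of 700 nM to 20000 nM.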

Compound 3, half-maximal inhibitory concentration: 2550 nM
For compound 3 the middle estimate is 1.4-fold (0.14 log units) above the measured one; measured number inside the range.
By their numbers in this assay, from the lowest: compound 2; then compound 3; then compound 1.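

In this assay there is now a single-change reading: hydrogen in place of chloro on an aromatic carbon, ortho to two chloro groups, gives a 2.1-fold higher number from compound 2 to compound 3 (0.33 log units; beyond the scatter) and so lies beyond the scatter. The step is modest, so inhibition in the low micromolar region persists without this chloro. Nothing at hand explains the step.

Still open, as far as these compounds go, is how another group at this position, such as fluoro, methoxy or an amine, would compare with chloro and hydrogen. Also open, from the compounds shown here alone, is whether either remaining chloro matters to a similar degree.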